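The source may hold more compounds than are shown below. What is called first, only, known or untested is meant among the compounds shown, and "the series" means these compounds.

Working notes on the series. In an assay for inhibition of steroid 17-alpha-hydroxylase/17,20 lyase (Homo sapiens), tested at 2 uM (a lower number here means a weaker effect, a higher number a stronger effect of the compound at the concentration tested), compound 1 `COc1ccc2cc(-c3cccnc3)ccc2c1-c1ccc(F)cc1` gives 1%, compound 2 `COc1ccc2cc(-c3cccc(-c4cccnc4)c3)ccc2c1` gives 4%, and compound 3 `COc1ccc2cc(-c3cccc(-c4ccncc4)c3)ccc2c1` gives 23%. Going by the values given here, compound 3 thus stands highest of the three numbers, separated from compound 2 and from compound 1 by more than the scatter; the single traced step, a number 19 percentage points higher from compound 2 to compound 3 (beyond the scatter), is what lifts compound 3 above compound 2.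

Compound 4 `Oc1ccc2cc(-c3cccc(-c4ccncc4)c3)ccc2c1` differs from compound 3 by hydrogen in place of methyl on an oxygen on an aromatic ring. Among the compounds with values here, no measured pair in the set exchanges hydrogen for methyl on that oxygen. Within the data shown here, the only traced step, a number 19 percentage points higher from compound 2 to compound 3 (beyond the scatter), concerns the pyridinyl exchange and does not bear on the present change, so there is nothing to read across from. The step of a number 1 percentage points lower from compound 3 to compound 4 (within the scatter) is therefore expected to stay within the scatter, with no direction favoured over the other. For compound 4 in this assay the estimate is 22%, with a range from 5% to 45%.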

Compound 4, a percentage reported as inhibition, at one concentration (the size of the read-out at that concentration, not a potency): 66%
For compound 4 the middle estimate is 44 percentage points below the measured one, outside the stated range (above it).
By their numbers in this assay, from the lowest: compounds 1 and 2 (each within the scatter of the next); then compound 3; then compound 4.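

On the oxygen on an aromatic ring, hydrogen in place of methyl gives a large step in this assay, a number 43 percentage points higher from compound 3 to compound 4 (beyond the scatter), whereas the pyridinyl exchange gave only a modest one, a number 19 percentage points higher from compound 2 to compound 3 (beyond the scatter). Going by these compounds alone, this is the first sign that this position matters, and that the methoxy group of compound 3 is not a neutral feature there. The change has been traced on this one pair only, so it establishes no general rule for the series. No measurement shown here accounts for the size of this step.

On these data alone, whether methoxy to hydroxy lifts the number as far with the pyridin-3-yl group of compound 2 remains open. So does the outcome with an amine or a fluorine in place of the hydroxy, or a longer chain such as ethoxy on that oxygen.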